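The source may report more compounds than this note shows. Statements on the series, on what has been measured and on what is new or still open speak of the compounds shown alone.

Measured compounds:
- compound 1 `COc1cccc(OC)c1C(=O)NCCNc1nc2cc(C)cc(C)c2cc1C#N`, in an in vitro assay on FRT cells with Cystic fibrosis transmembrane conductance regulator variant F508del (Homo sapiens) as the target, read by fluorescence, with a stated time of 24 h, at 37 degrees C, in the presence of a further agent that is not named here (a lower number here means that less compound is needed, a higher number that more compound is needed for the effect), compound 1 gives 3700 nM
- compound 2 `Cc1cc(C)c2cc(C#N)c(N3CCN(C(=O)c4ccncc4)CC3)nc2c1`, in this assay compound 2 gives "not active" (no number reported)
- compound 3 `COc1ccccc1C(=O)NCCCNc1nc2cc(C)cc(C)c2cc1C#N`, in this assay compound 3 gives "not active" (no number reported)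

Compound 3 stands without a single number in this assay, and it is not alone in that: compound 2 also has no number reported there. Only compound 1 carries a value, and its reading is far from potent. Within the data shown here, nothing beyond these three compounds is known about the series, so no step between measured compounds can be drawn.

The move from compound 3 to compound 4 `COc1ccc(C(=O)NCCCNc2nc3cc(C)cc(C)c3cc2C#N)cc1` keeps every atom and changes only how they are joined: 4-methoxyphenyl in place of 2-methoxyphenyl on a carbonyl carbon. Compound 4 shares its whole linker and core with compound 3, which had no reported activity, and its closest numbered relative, compound 1, is itself weak. The change in the methoxyphenyl group is the only difference, and nothing in the data shows that such a change moves the read-out. The expectation for compound 4 is therefore weak or no activity, most likely a reading that again ends without a number.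

Compound 4 is expected in this assay at about 12000 nM, within a range from 3000 nM to 50000 nM.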

Compound 4, half-maximal effective concentration: 4300 nM
Compound 4: middle estimate off by 2.8-fold (0.45 log units), on the high side; low and high end bracket the measured number.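

In this assay, among these compounds, compound 4 gives 4300 nM while compound 3 has no number, so no step from compound 3 to compound 4 can be read. No evidence shown here bears on this result. The compounds shown leave open whether exchanging 2-methoxyphenyl for 4-methoxyphenyl itself moves the read-out.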